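Alkyne terminus exchange on the core of compound 1

The compounds below may be only part of what the source reports. "The series", "measured", "known", "first", "only" and "open" are said of these compounds alone.

Compound 1 `O=c1[nH]c(=O)n([C@H]2C[C@H](O)[C@@H](CO)O2)cc1C#CI` gives 200000 nM in an ADME assay on HEL cells (Homo sapiens) for cytotoxicity; on this read-out lower numbers stand for higher toxicity in this test and higher numbers for lower toxicity in this test. Compound 2 `C[Si](C)(C)C#Cc1cn([C@@H]2O[C@H](CO)[C@@H](O)[C@@H]2O)c(=O)[nH]c1=O` gives 200000 nM in this assay, level with compound 1 at the digits shown and within the scatter. Compound 3 `CC(=O)OC[C@H]1O[C@@H](n2cc(C#CI)c(=O)[nH]c2=O)[C@@H](OC(C)=O)[C@@H]1OC(C)=O` gives 50000 nM, a lower number than compound 1 and beyond the scatter, so compound 1 stands together with compound 2 at the highest number of the three. Compound 4 `C[Si](C)(C)C#Cc1cn([C@H]2C[C@H](O)[C@@H](CO)O2)c(=O)[nH]c1=O` is not yet measured. The change from compound 1: a group of 4 heavy atoms (3 carbon, 1 silicon; no ring) in place of one iodine atom, on a triple-bonded carbon. Among the compounds with values here, no measured pair shows this change alone; compound 2 carries the same entering group on a different remainder and gives 200000 nM. A step of no change at the digits printed from compound 1 to compound 4 (within the scatter) is expected, none beyond the scatter. Compound 4 is estimated at 200000 nM, between 100000 nM and 400000 nM.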

Compound 4, minimum cytotoxic concentration: 200000 nM
Compound 4: the middle estimate sits on the measured number at the digits printed; measured number inside the range.
By their numbers in this assay, from the lowest: compound 3; then compounds 1, 2 and 4 (each within the scatter of the next).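

In this assay, within the data shown here, the group of 4 heavy atoms (3 carbon, 1 silicon) in place of iodo on the triple-bonded carbon gives no change at the digits printed from compound 1 to compound 4 (within the scatter) on the core of compound 1, the first direct reading of this exchange. Hydrogen in place of hydroxy on a saturated ring carbon gives no change at the digits printed from compound 2 to compound 4 (within the scatter) with the silicon-bearing group held fixed. No evidence on hand bears on these results. From the compounds shown here alone, whether an amine, a carboxylic acid or a longer alkyl chain on the triple-bonded carbon would separate from compound 1 remains open.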